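Shortening the amide chain: compound 2 to compound 3

A few compounds are considered here, and "the series" means these few. Any claim that something is new, unique, unknown or untested is made for them only; others in the source may bear on it.

Measured so far in an assay on isolated protein for inhibition of MAP kinase-interacting serine/threonine-protein kinase 2 (Homo sapiens), read by HTRF, in the presence of a further agent that is not named here; on this read-out lower numbers stand for stronger inhibition and higher numbers for weaker inhibition:
- compound 1, `Cc1c(C(=O)N2CCOCC2)oc2ccc(Nc3ncnc4ccc(Cl)nc34)cc12`: 1800 nM
- compound 2, `CCCNC(=O)c1oc2ccc(Nc3ncnc4ccc(Cl)nc34)cc2c1C`: 1900 nM

Among the measured compounds shown here, compound 2 gives the higher of the two numbers in this assay, but its only neighbour, compound 1, sits within the scatter: a 1.1-fold higher number from compound 1 to compound 2 (0.02 log units; within the scatter). The two values show that exchanging the morpholin-4-yl for propylamino on the carbonyl carbon left the read-out essentially unchanged.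

Compound 3, `CNC(=O)c1oc2ccc(Nc3ncnc4ccc(Cl)nc34)cc2c1C`, is not yet measured. It differs from compound 2 in one place: hydrogen in place of ethyl on a saturated chain carbon bound to an amide-type nitrogen, which cut one bond further out reads propylcarbamoyl to methylcarbamoyl.

For the measured compounds named here, only one measured step bears on this position, the exchange on the carbonyl carbon from compound 1 to compound 2, and that step stayed within the scatter. With a single step of that kind available, no direction beyond the scatter is expected for compound 3 in this assay; the expected step is a 1.1-fold higher number from compound 2 to compound 3 (0.02 log units; within the scatter).

Compound 3 is estimated at 2000 nM, with a range from 900 nM to 4500 nM.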

Compound 3, half-maximal inhibitory concentration: 2500 nM
For compound 3 the middle estimate is 1.3-fold (0.10 log units) below the measured one; low and high end bracket the measured number.
By their numbers in this assay, from the lowest: compounds 1, 2 and 3 (each within the scatter of the next).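

In this assay, removing ethyl from the saturated chain carbon bound to an amide-type nitrogen gives a 1.3-fold higher number from compound 2 to compound 3 (0.12 log units; within the scatter), so shortening propylcarbamoyl to methylcarbamoyl does not move the read-out beyond the scatter. Methylamino in place of morpholin-4-yl on the carbonyl carbon gives a 1.4-fold higher number from compound 1 to compound 3 (0.14 log units; within the scatter), so morpholin-4-yl, propylamino and methylamino all lie within the scatter of one another at this place. No measurement available here speaks to the reason for this flat result.

From the compounds shown here alone, it remains open whether a carboxylic acid, a primary amide or an aminoethyl chain on this carbonyl carbon would shift the number beyond the scatter. The compounds shown also leave open whether any exchange at this place can change the read-out, in either direction, while the rest of the shared core stays the same.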